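Salicylanilide series: ring chlorination and macrophage cytotoxicity

This account rests on a few compounds, and the source may have more. Where it says the series, first, only, none or still open, it means among the compounds named here.

Measured compounds in an ADME assay on cells (Macrophage, Mus musculus) for cytotoxicity, read by resazurin assay, with a stated time of 3 days; a higher number here means a weaker inhibitor, a lower number a stronger inhibitor:
compound 1 `O=C(Nc1cccc(C(F)(F)F)c1)c1cc(Cl)ccc1O` gives 5900 nM.
compound 2 `O=C(Nc1ccccc1C(F)(F)F)c1cc(Cl)ccc1O` gives 19000 nM.
compound 3 `O=C(Nc1cc(C(F)(F)F)ccc1Cl)c1cc(Cl)ccc1O` gives 3500 nM.

Compound 3 comes out of compound 1 by chloro in place of hydrogen on an aromatic carbon; the size of that step is a 1.7-fold lower number from compound 1 to compound 3 (0.23 log units; within the scatter). Compound 2 shares its atoms with compound 1, joined differently; the difference between the two cores is not broken down here. Compound 2 stands highest of the three in this assay, and its gap to compound 1 and to compound 3 is beyond the scatter.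

Compound 4 `O=C(Nc1c(Cl)cccc1C(F)(F)F)c1cc(Cl)ccc1O` is not yet measured. It comes out of compound 2 by chloro in place of hydrogen on an aromatic carbon. For the measured compounds named here, this is the same kind of change as the one from compound 1 to compound 3, though the place differs: in compound 3 the entering chloro is para to a trifluoromethyl group, in compound 4 it is meta to a trifluoromethyl group.

Going by the values given here, on the single precedent, compound 4 is expected to move by about a 1.5-fold lower number from compound 2 to compound 4 (0.16 log units; within the scatter) in this assay, because the matching step a 1.7-fold lower number from compound 1 to compound 3 (0.23 log units; within the scatter) stayed within the scatter. Compound 4 is therefore estimated at 13000 nM, with a likely range from 5000 nM to 35000 nM.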

Compound 4, half-maximal inhibitory concentration: 23000 nM
For compound 4 the middle estimate is 1.8-fold (0.25 log units) below the measured one, within the range that was stated.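

In this assay, chloro in place of hydrogen on an aromatic carbon gives a 1.2-fold higher number from compound 2 to compound 4 (0.08 log units; within the scatter), so on the core of compound 2, as on the core of compound 1, the step stays inside the scatter. For the compounds shown here, with only two steps, and the entering chloro at a different place on each core, this does not show that the change carries over to other cores, nor does it settle whether the place of the chloro matters. The two steps cannot be told apart, and the change reads as equally small on both cores: the same change on two cores in this assay, a 1.7-fold lower number (0.23 log units; within the scatter) from compound 1 to compound 3 and a 1.2-fold higher number (0.08 log units; within the scatter) from compound 2 to compound 4, 2.0-fold (0.31 log units) apart, within the scatter of two such steps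

The compounds shown leave open whether another group at the same place, such as a methoxy group, a nitrile or an amine, would move the number beyond the scatter. Also open, as far as these compounds go, is whether the chloro step would stay as small on a core carrying no trifluoromethyl group, or with the chloro shared by all four compounds replaced by a bromo group.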